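The source may report more compounds than this note shows. Statements on the series, on what has been measured and on what is new or still open speak of the compounds shown alone.

Measured in an assay on cell membranes for binding affinity to 2-oxoglutarate receptor 1 (Rattus norvegicus), read by radioligand binding; on this read-out higher numbers stand for weaker inhibition and lower numbers for stronger inhibition:
Compound 1 `CCCCCNC(=O)[C@H]1O[C@@H](n2cnc3c(N)ncnc32)[C@H](O)[C@@H]1O` gives 12 nM.
Compound 2 `CCCCCCCCNC(=O)[C@H]1OC(n2cnc3c(N)ncnc32)[C@H](O)[C@@H]1O` gives 21 nM.
Compound 3 `CCCCCCCCCCCNC(=O)[C@H]1OC(n2cnc3c(N)ncnc32)[C@H](O)[C@@H]1O` gives 123 nM.

Compound 2 stands second highest of these three numbers. Its gap to compound 1 lies within the usual scatter, so the two cannot be ranked against each other, while compound 3 sits clearly further off, with a 5.9-fold higher number from compound 2 to compound 3 (0.77 log units; beyond the scatter). Among the compounds with values here, that step, which extends the chain by a propyl, is the only single-point change measured here, and it points one way: a longer chain goes with a weaker result.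

Compound 4 `CC(=O)NCCNC(=O)[C@H]1OC(n2cnc3c(N)ncnc32)[C@H](O)[C@@H]1O` has not yet been measured. Against compound 2 it shows (acetamido in place of hexyl on a saturated chain carbon, two bonds along the chain from an amide-type nitrogen). Cut one bond further out, the same change reads octyl to 2-acetamidoethyl, so the chain becomes shorter and takes on an amide-type group. Within the data shown here, the measured step runs the opposite way, lengthening rather than shortening, and no measured compound carries such a group in this chain, so it bears on compound 4 only indirectly. The values of compound 1 and compound 2 show that going from octyl down to pentyl stays within the scatter. The expectation in this assay for the step from compound 2 to compound 4 is therefore a 1.9-fold higher number from compound 2 to compound 4 (0.28 log units; within the scatter), modest at most and of uncertain direction. Compound 4 is estimated at 40 nM, within a range from 8 nM to 250 nM.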

Compound 4, inhibition constant: 46 nM
Compound 4: the middle estimate sits 1.2-fold (0.06 log units) below what was measured, within the range that was stated.
By their numbers in this assay, from the lowest: compounds 1 and 2 (each within the scatter of the next); then compound 4; then compound 3.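

In this assay, putting 2-acetamidoethyl in place of the octyl chain gives a 2.2-fold higher number from compound 2 to compound 4 (0.34 log units; beyond the scatter) and so shows that this position tolerates a short chain carrying a second amide-type group at only a modest cost, something the plain alkyl chains could not reveal. Against the longest chain, the same kind of change gives a 2.7-fold lower number from compound 3 to compound 4 (0.43 log units; beyond the scatter) and places compound 4 within the span of values set by compound 2 and compound 3, so adding the acetamido group does not take the compound outside what the plain chains already cover. Nothing measured here gives a reason for either shift.

As far as these compounds go, it remains open whether the value of compound 4 follows from the acetamido group itself or simply from the shorter chain, and a plain butyl chain in the same place would help separate the two readings. Placing an amine or a carboxylic acid at the end of the chain would show whether other groups are accepted here as well as the acetamido group.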